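A few compounds are considered here, and "the series" means these few. Any claim that something is new, unique, unknown or untested is made for them only; others in the source may bear on it.

The shared core of the series is seen in compound 1 `OCc1cn(CCNc2nonc2/C(=N/O)Nc2ccc(F)c(Br)c2)nn1`. In an assay on isolated protein for inhibition of Indoleamine 2,3-dioxygenase 2 (Homo sapiens) (on this read-out lower numbers stand for stronger inhibition and higher numbers for weaker inhibition), compound 1 gives 794 nM; among the three measured compounds its number stands second highest, with compound 2 nearest and compound 3 furthest away. Compound 2 `OCCc1cn(CCNc2nonc2/C(=N/O)Nc2ccc(F)c(Br)c2)nn1` gives 1170 nM in this assay, and the step of a 1.5-fold higher number from compound 1 to compound 2 (0.17 log units; within the scatter) stays within the scatter. Compound 3 `OCCOCc1cn(CCNc2nonc2/C(=N/O)Nc2ccc(F)c(Br)c2)nn1` gives 144 nM in this assay; the step of a 5.5-fold lower number from compound 1 to compound 3 (0.74 log units; beyond the scatter) lies beyond the scatter, as does an 8.1-fold lower number from compound 2 to compound 3 (0.91 log units; beyond the scatter).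

Compound 4 `CC(C)(OCCO)c1cn(CCNc2nonc2/C(=N/O)Nc2ccc(F)c(Br)c2)nn1` is not yet measured. Its difference from compound 1 is 1-(2-hydroxyethoxy)-1-methylethyl in place of hydroxymethyl on an aromatic carbon. The change keeps the 2-hydroxyethoxy part that set compound 3 apart from compound 1 and folds it into a 1-(2-hydroxyethoxy)-1-methylethyl group. The step that bears most directly on it is a 5.5-fold lower number from compound 1 to compound 3 (0.74 log units; beyond the scatter); the step of a 1.5-fold higher number from compound 1 to compound 2 (0.17 log units; within the scatter) shows that hydroxymethyl in place of hydroxy alone changed little. Among the compounds with values here, no measured pair shows the effect of the added methyl groups, so the expected step is taken as a lower number of a size close to that seen for compound 3, with a wider range. The estimated step is a 4.0-fold lower number from compound 1 to compound 4 (0.60 log units; beyond the scatter). For compound 4 in this assay the estimate is 200 nM, with a range from 80 nM to 500 nM.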

Compound 4, half-maximal inhibitory concentration: 1170 nM
Compound 4: the middle estimate sits 5.9-fold (0.77 log units) below what was measured; the measured number lies above the stated range.
By their numbers in this assay, from the lowest: compound 3; then compounds 1, 2 and 4 (each within the scatter of the next).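

On the aromatic carbon of the five-membered aromatic ring with 3 nitrogen, the 2-hydroxyethoxy part does not by itself carry the gain seen in compound 3: 1-(2-hydroxyethoxy)-1-methylethyl in place of (2-hydroxyethoxy)methyl gives (an 8.1-fold higher number from compound 3 to compound 4 (0.91 log units; beyond the scatter)). Within the data shown here, the position therefore responds to the carbon that joins this part to the ring, and not only to the presence of the part, since the added methyl groups on that carbon are the one difference in this pair. Despite 7 heavy atoms entering and 2 leaving, the larger group stays level with the small hydroxy-bearing groups, with (a 1.5-fold higher number from compound 1 to compound 4 (0.17 log units; within the scatter)) and (no change at the digits printed from compound 2 to compound 4 (within the scatter)), and nothing at hand gives a reason for the loss between compound 3 and compound 4.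

Still open, from the compounds shown here alone, is whether a single methyl on that carbon, as in 1-(2-hydroxyethoxy)ethyl, already accounts for the loss or whether both methyl groups are needed. Also open, going by these compounds, is whether compound 3's number survives a longer chain such as (3-hydroxypropoxy)methyl, or an amine or a carboxylic acid in place of the terminal hydroxy.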